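The source may hold more compounds than are shown below. What is called first, only, known or untested is meant among the compounds shown, and "the series" means these compounds.

Measured so far in a functional assay (muscle tissue) with Cavia porcellus as the target; on this read-out higher numbers stand for an effect only at larger amounts of compound and lower numbers for an effect already at smaller amounts:
compound 1 `C=Cc1ccccc1C1C(C(=O)OC)=C(C)N=C(C)/C1=C(\O)OC` gives 4.47 nM;
compound 2 `COC(=O)C1=C(C)N=C(C)/C(=C(\O)OC)C1c1cccc(Cl)c1Cl` gives 19.1 nM;
compound 3 `COC(=O)C1=C(C)N=C(C)/C(=C(\O)OC)C1c1cc(Cl)cc(Cl)c1` gives 93.3 nM.

Compound 3 stands highest of the three numbers in this assay, with a 4.9-fold higher number from compound 2 to compound 3 (0.69 log units; beyond the scatter) and a 21-fold higher number from compound 1 to compound 3 (1.32 log units; beyond the scatter). Compound 4 `CCc1ccccc1C1C(C(=O)OC)=C(C)N=C(C)/C1=C(\O)OC` differs from compound 3 in one place: 2-ethylphenyl in place of 3,5-dichlorophenyl on a saturated ring carbon. The step that bears most on this change runs the other way from compound 1 to compound 3, where the 2-vinylphenyl was lost: a 21-fold higher number from compound 1 to compound 3 (1.32 log units; beyond the scatter). Since the 2-ethylphenyl of compound 4 resembles the 2-vinylphenyl of compound 1 more than the 3,5-dichlorophenyl of compound 3, a large step to a lower number is expected, a 16-fold lower number from compound 3 to compound 4 (1.19 log units; beyond the scatter). Compound 4 is therefore estimated at 6 nM, within 2 nM to 20 nM.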

Compound 4, half-maximal effective concentration: 6.46 nM
The estimate for compound 4 lay 1.1-fold (0.03 log units) below the measured number; the range from low to high includes it.
By their numbers in this assay, from the lowest: compounds 1 and 4 (each within the scatter of the next); then compound 2; then compound 3.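

In this assay, the change to 2-ethylphenyl gives a 14-fold lower number from compound 3 to compound 4 (1.16 log units; beyond the scatter), and from the other dichlorophenyl it gives a 3.0-fold lower number from compound 2 to compound 4 (0.47 log units; beyond the scatter), so both dichlorophenyl compounds differ clearly from this group on the saturated ring carbon. Ethyl in place of vinyl gives a 1.4-fold higher number from compound 1 to compound 4 (0.16 log units; within the scatter), which lies within the scatter, so the vinyl double bond is not needed for a number in this range. No measured evidence accounts for these differences. The compounds shown leave open whether a longer chain such as propyl, or an amine, in place of the ethyl would keep the number in this range.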